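The compounds below may be only part of what the source reports. "The series", "measured", "known", "first", "only" and "open" are said of these compounds alone.

Measured compounds:
- compound 1 `Cc1ccc2[nH]c(-c3ccc(-c4ccc(-c5cccc(Cl)c5)cc4)cc3)nc2c1`: 3600 nM
- compound 2 `COc1ccc(-c2ccc(-c3ccc(-c4nc5cc(C)ccc5[nH]4)cc3)cc2)cc1OC`: 3510 nM
- compound 3 `Clc1cccc(-c2ccc(-c3ccc(-c4nc5ccccc5[nH]4)cc3)cc2)c1`: 100000 nM

In a functional assay on SiHa cells (Homo sapiens) for inhibition, read by sulforhodamine B assay (a lower number here means a stronger inhibitor of growth, a higher number a weaker inhibitor of growth), compound 1 gives 3600 nM and compound 2 gives 3510 nM. The step between them, a 1.0-fold lower number from compound 1 to compound 2 (0.01 log units; within the scatter), comes from this change: 3,4-dimethoxyphenyl in place of 3-chlorophenyl on an aromatic carbon. Compound 3 differs from compound 1 only in its core, by hydrogen in place of methyl on an aromatic carbon, and the step of a 28-fold higher number from compound 1 to compound 3 (1.44 log units; beyond the scatter) is large; compound 3 stands with the highest number of the three in this assay.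

Compound 4 `COc1ccc(-c2ccc(-c3ccc(-c4nc5ccccc5[nH]4)cc3)cc2)cc1OC` is not yet measured. It arises from compound 3 by 3,4-dimethoxyphenyl in place of 3-chlorophenyl on an aromatic carbon, the same change that turns compound 1 into compound 2, made on the core of compound 3 instead. Going by the values given here, the only guide is the step of a 1.0-fold lower number from compound 1 to compound 2 (0.01 log units; within the scatter), which lay within the scatter. On that basis the step from compound 3 to compound 4 is expected to be similar, about a 1.1-fold lower number from compound 3 to compound 4 (0.05 log units; within the scatter), so compound 4 is expected to sit near compound 3 in this assay. The estimate for compound 4 is 90000 nM, with a range from 30000 nM to 250000 nM; given how weak compound 3 is, a limit rather than a number is possible.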

Compound 4, concentration for 50% growth inhibition: 6200 nM
Beside the measured number, compound 4's estimate is 15-fold (1.16 log units) above it, and the stated range ends above it.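

In this assay, 3,4-dimethoxyphenyl in place of 3-chlorophenyl does not carry over from one core to the other, as the change gives a 16-fold lower number from compound 3 to compound 4 (1.21 log units; beyond the scatter) on the core without the methyl: the same change on two cores in this assay, a 1.0-fold lower number (0.01 log units; within the scatter) from compound 1 to compound 2 and a 16-fold lower number (1.21 log units; beyond the scatter) from compound 3 to compound 4, 16-fold (1.20 log units) apart, beyond the scatter of two such steps

Read along the other edge, the loss of the methyl depends on the group at the far end of the molecule, with only a 1.8-fold higher number from compound 2 to compound 4 (0.25 log units; within the scatter) in the dimethoxy pair: the same change on two cores in this assay, a 28-fold higher number (1.44 log units; beyond the scatter) from compound 1 to compound 3 and a 1.8-fold higher number (0.25 log units; within the scatter) from compound 2 to compound 4, 16-fold (1.20 log units) apart, beyond the scatter of two such steps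

These two gaps are one observation on the same four compounds, with both large steps running to or from compound 3, so they show non-additivity in this one set but neither a cause nor a rule for the series.

Open, going by these compounds, is whether the same dependence appears with an amine or a carboxylic acid in place of the 3-chlorophenyl, or with an ethyl group in place of the methyl on the core. Also open, on these data alone, is whether the high number of compound 3 holds up on repeated measurement.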